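A Larger Aromatic Group in Place of Isopropyl

The source may hold more compounds than are shown below. What is called first, only, known or untested is meant among the compounds shown, and "the series" means these compounds.

Measured so far:
compound 1, `CC(C)c1cccc(NC(=O)CCc2cccc3c2B(O)OC3)c1`, 510 nM
compound 2, `O=C(CCc1cccc2c1B(O)OC2)Nc1cccc2ccccc12`, 170 nM

Of the compounds shown here, two have been tested in a functional assay on SK-OV-3 cells (Homo sapiens) for antiproliferative activity, read by MTT assay, with a stated time of 72 h; a lower number here means a stronger inhibitor, a higher number a weaker inhibitor. Both share the same core, a boron-containing bicyclic unit joined through a short chain to an amide, and differ only in the group attached to the amide nitrogen. Compound 1, which carries an isopropyl group on that aromatic ring, gives 510 nM in this assay. Compound 2 carries a naphthyl group instead and gives 170 nM. Of the two numbers, compound 1 stands at the higher one, and the gap to compound 2 lies beyond the usual scatter.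

The next compound, compound 3, `CSc1ccc(-c2cccc(NC(=O)CCc3cccc4c3B(O)OC4)c2)cc1`, keeps the core and the amide of compound 1 and changes one place: 4-(methylsulfanyl)phenyl in place of isopropyl on an aromatic carbon. Among the measured compounds shown here, no step between two measured compounds isolates this kind of change, so the expectation rests on the two values alone. Compound 2, with a larger aromatic group, gives 170 nM, whereas compound 1 gives 510 nM. On that basis a moderate move to a lower number seems plausible for compound 3, so the estimated step is a 2.0-fold lower number from compound 1 to compound 3 (0.31 log units; beyond the scatter). Compound 3 is therefore estimated at 250 nM, with a range from 80 nM to 800 nM.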

Compound 3, half-maximal inhibitory concentration: 140 nM
Compound 3: the middle estimate sits 1.8-fold (0.25 log units) above what was measured; low and high end bracket the measured number.
By their numbers in this assay, from the lowest: compounds 3 and 2 (each within the scatter of the next); then compound 1.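

In this assay, among the compounds shown here, putting 4-(methylsulfanyl)phenyl in place of isopropyl on this aromatic carbon gives a 3.6-fold lower number from compound 1 to compound 3 (0.56 log units; beyond the scatter), the first step between measured compounds that isolates a single change at this place. The entering group has 8 heavy atoms against 3 for isopropyl and brings a six-membered aromatic ring, so this place accepts a much larger group here, and the number falls rather than rises. No measurement shown here bears on what lies behind this step.

The compounds shown leave open whether the step comes from the added ring itself or from the methylsulfanyl group it carries, and a plain phenyl group at this place would separate the two. On these data alone, it also remains open how much the result depends on what sits at the end of that ring, which a carboxylic acid or an amine in place of the methylsulfanyl group would begin to test.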